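Swapping a dimethylpiperidinyl group for tetrahydroquinolinylmethyl

This account rests on a few compounds, and the source may have more. Where it says the series, first, only, none or still open, it means among the compounds named here.

Compound 1 `COc1cccc(CN2C(=O)CN(C(=O)c3cc4cc(OC)ccc4[nH]3)C[C@@H]2CCc2ccccc2)c1` gives 4500 nM in an ADME assay on Vero cells (Chlorocebus sabaeus) for cytotoxicity, with a stated time of 7 days; a higher number here means that more compound is tolerated, a lower number that less compound is tolerated.
Compound 2 `COc1cccc(CN2C(=O)CN(C(=O)c3cc4cc(OC)ccc4[nH]3)C[C@@H]2c2ccccc2)c1` reaches only the limit of this assay, > 10000 nM.
Compound 3 `COc1ccc2[nH]c(C(=O)N3CC(=O)N(Cc4ccccc4)[C@@H](N4[C@H](C)CCC[C@@H]4C)C3)cc2c1` gives 1400 nM.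

Compound 3 thus has the lowest of the two numbers, so less of it is tolerated than of compound 1. Compound 4 `COc1ccc2[nH]c(C(=O)N3CC(=O)N(Cc4ccccc4)[C@@H](CN4CCCc5ccccc54)C3)cc2c1` differs from it in one place: (1,2,3,4-tetrahydroquinolin-1-yl)methyl in place of 2,6-dimethylpiperidin-1-yl on a saturated ring carbon. Going by the values given here, only one measured step concerns a change on a saturated ring carbon of the shared core, an at least 2.2-fold higher number from compound 1 to compound 2 (0.34 log units; beyond the scatter), where an aromatic ring in place of a chain raised the number. The present change also brings in an aromatic ring, so a modest rise is expected, a 2.1-fold higher number from compound 3 to compound 4 (0.33 log units; beyond the scatter). Compound 4 is therefore estimated at 3000 nM, between 1000 nM and 9000 nM.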

Compound 4, half-maximal cytotoxic concentration: > 100000 nM
Compound 4: only a limit was reported; the forecaster's own chance of this, stated with the estimate: 20%; middle value at least 33-fold (1.52 log units) from the limit.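

In this assay, this position on a saturated ring carbon proves highly sensitive to the group it carries, with an at least 71-fold higher number from compound 3 to compound 4 (1.85 log units; beyond the scatter). On these data alone, compound 4 gives > 100000 nM, which is a limit of the assay and not a number, so the full size of this step stays unknown. The change also turns the lowest number shown into the highest limit shown.

The compounds shown do not separate the effect of the aromatic ring from that of the methyl linker or the lost dimethyl groups. A piperidin-1-ylmethyl group here would help to tell these apart.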